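This account rests on a few compounds, and the source may have more. Where it says the series, first, only, none or still open, it means among the compounds named here.

Within the data shown here, compound 3 `COc1cc(OC)c2c(=O)cc(-c3ccc(OCc4cn(-c5ccc(Cl)cc5)nn4)c(OC)c3)oc2c1` is one of three compounds measured in an ADME assay on Huh-7 cells (Homo sapiens) for cytotoxicity, read by MTT assay, with a stated time of 72 h; on this read-out higher numbers stand for lower toxicity in this test and lower numbers for higher toxicity in this test. In this assay compound 3 gives > 100 ug/mL, which is a limit of the assay and not a number. Compound 2 `COc1cc(OC)c2c(=O)cc(-c3ccc(OCc4cn(-c5ccc(F)cc5F)nn4)c(OC)c3)oc2c1` also gives a limit, > 100 ug/mL. Compound 1 `COc1cc(O)c(C(=O)/C=C/c2ccc(OC)c(OCc3cn(-c4ccccc4Cl)nn3)c2)c(OC)c1` likewise gives a limit, > 100 ug/mL. Among the measured compounds shown here, all three values thus sit at the limit of > 100 ug/mL in this assay, at which 3 of the 3 values shown sit, and the one step between neighbours, a step that the two limits leave unreadable from compound 2 to compound 3, cannot be read. Compound 4 `COc1cc(OC)c2c(=O)cc(-c3ccc(OCc4cn(-c5ccc(F)cc5Cl)nn4)c(OC)c3)oc2c1` has not been measured in this assay and differs from compound 3 by 2-chloro-4-fluorophenyl in place of 4-chlorophenyl on an aromatic nitrogen. For the measured compounds named here, the only step that bears on this change carries no readable size, so no step beyond the scatter is expected. Compound 4 is therefore expected to stay at the same limit, with an estimated step of a number no higher from compound 3 to compound 4 (the limit leaves the size open). Compound 4 is expected to give 100 ug/mL, between 50 ug/mL and 200 ug/mL.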

Compound 4, half-maximal cytotoxic concentration: > 100 ug/mL
Compound 4 ended at the assay's limit; the forecaster's own chance of this, stated with the estimate: 85%; the middle value lies on the limit itself.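

Compound 4 also ends at a limit of the assay, so the steps linking compound 2, compound 3 and compound 4 in this assay cannot be read: the limit of > 100 ug/mL in this assay, at which 4 of the 4 values shown sit.

The compounds shown leave open whether changing the group on the aromatic nitrogen alters toxicity in this test at all.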